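Swapping chloro for fluoro on a second core

This account rests on a few compounds, and the source may have more. Where it says the series, first, only, none or still open, it means among the compounds named here.

Compound 1 `N#Cc1c(NCc2ccccc2)c(Cl)c2nc(N)nc(N)c2c1F` gives 0.8 ug/mL in a functional assay on SK-OV-3 cells (Homo sapiens) for cytotoxicity, read by MTT assay; a lower number here means a stronger inhibitor, a higher number a weaker inhibitor. Compound 2 `N#Cc1c(NCc2ccccc2)c(F)c2nc(N)nc(N)c2c1F` differs from compound 1 by fluoro in place of chloro on an aromatic carbon, and this change gave a 14-fold higher number from compound 1 to compound 2 (1.14 log units; beyond the scatter). In this assay compound 2 gives 11 ug/mL. Compound 3 `CC(C)(C)Nc1c(C#N)c(F)c2c(N)nc(N)nc2c1Cl` has a different core, differing from compound 1 by tert-butyl in place of benzyl on a nitrogen on an aromatic ring, a step of a 2.6-fold higher number from compound 1 to compound 3 (0.42 log units; beyond the scatter). In this assay compound 3 gives 2.1 ug/mL. Compound 4 `CC(C)(C)Nc1c(C#N)c(F)c2c(N)nc(N)nc2c1F` is not yet measured and differs from compound 3 by fluoro in place of chloro on an aromatic carbon. This is the same kind of change as from compound 1 to compound 2, though the surroundings differ: here the carbon is ortho to a (tert-butyl)amino group, whereas before it was ortho to a benzylamino group. Because a 14-fold higher number from compound 1 to compound 2 (1.14 log units; beyond the scatter) was large, a step of a 10-fold higher number from compound 3 to compound 4 (1.02 log units; beyond the scatter) is expected here. Compound 4 is therefore expected to give 22 ug/mL, likely between 7 ug/mL and 65 ug/mL.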

Compound 4, half-maximal inhibitory concentration: 2.4 ug/mL
Compound 4: middle estimate off by 9.2-fold (0.96 log units), on the high side, outside the stated range (below it).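

In this assay, fluoro in place of chloro on an aromatic carbon does not carry over as one fixed step, as here it gives a 1.1-fold higher number from compound 3 to compound 4 (0.06 log units; within the scatter), far from the earlier result: the same change on two cores in this assay, a 14-fold higher number (1.14 log units; beyond the scatter) from compound 1 to compound 2 and a 1.1-fold higher number (0.06 log units; within the scatter) from compound 3 to compound 4, 12-fold (1.08 log units) apart, beyond the scatter of two such steps

Tert-butyl in place of benzyl on the nitrogen also depends on its surroundings, giving a 4.6-fold lower number from compound 2 to compound 4 (0.66 log units; beyond the scatter), opposite in direction to the earlier step: the same change on two cores in this assay, a 2.6-fold higher number (0.42 log units; beyond the scatter) from compound 1 to compound 3 and a 4.6-fold lower number (0.66 log units; beyond the scatter) from compound 2 to compound 4, 12-fold (1.08 log units) apart, beyond the scatter of two such steps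

So in these four compounds, the effect of each change depends on the other group present, but they do not show why, or whether this holds for other groups.

As far as these compounds go, it remains open how bromo or methyl on that aromatic carbon would compare. A longer chain on the nitrogen, such as n-butyl, could follow either the benzyl or the tert-butyl pattern.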